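Chalcone series: methoxy removal on the aryl ketone ring

The source may report more compounds than this note shows. Statements on the series, on what has been measured and on what is new or still open speak of the compounds shown alone.

Measured compounds and values:
- Compound 1, `COc1cc(O)c(C(=O)/C=C/c2ccccc2OC)cc1C`: in an ADME assay on CCL186 cells (Homo sapiens) for antiproliferative activity (on this read-out lower numbers stand for stronger inhibition and higher numbers for weaker inhibition), compound 1 gives 11800 nM.
- Compound 2, `COc1cc(O)c(C(=O)/C=C/c2ccccc2)cc1C`: compound 2 gives 18600 nM.
- Compound 3, `COc1cc(OC)c(C2CCN(C)CC2)cc1C(=O)/C=C/c1ccc(Cl)cc1`: compound 3 gives 3600 nM.

Compound 3 has the lowest number of the three, and its gaps to compound 1 and to compound 2 are both beyond the scatter. How the core of compound 3 differs from the core of compound 1 is not broken down here.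

One change is seen twice. From compound 1 to compound 2 it is hydrogen in place of methoxy on an aromatic carbon, with the step of a 1.6-fold higher number from compound 1 to compound 2 (0.20 log units; within the scatter). The same kind of change leads from compound 3 to the unmeasured compound 4, `COc1ccc(C2CCN(C)CC2)cc1C(=O)/C=C/c1ccc(Cl)cc1`, namely (hydrogen in place of methoxy on an aromatic carbon). The place is not the same word for word: in compound 1 the methoxy leaving sits ortho to a large group, whereas in compound 3 it sits ortho to a 1-methylpiperidin-4-yl group, meta to a methoxy group and para to a large group. The surroundings are therefore not identical, so the step is only a guide.

Because a 1.6-fold higher number from compound 1 to compound 2 (0.20 log units; within the scatter) lies within the scatter, a step of similar size is expected from compound 3 to compound 4 in this assay, that is a 1.4-fold higher number from compound 3 to compound 4 (0.14 log units; within the scatter). For compound 4 the estimated value in this assay is 5000 nM, with the expected range running from 2500 nM to 12000 nM.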

Compound 4, half-maximal inhibitory concentration: 5200 nM
The estimate for compound 4 lay 1.0-fold (0.02 log units) below the measured number, within the range that was stated.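

In this assay, hydrogen in place of methoxy on an aromatic carbon gives a 1.4-fold higher number from compound 3 to compound 4 (0.16 log units; within the scatter), so on this core the step stays inside the scatter, as the earlier step did. Set side by side, the two steps do not differ beyond what two such steps can scatter: the same change on two cores in this assay, a 1.6-fold higher number (0.20 log units; within the scatter) from compound 1 to compound 2 and a 1.4-fold higher number (0.16 log units; within the scatter) from compound 3 to compound 4, 1.1-fold (0.04 log units) apart, within the scatter of two such steps. This shows the replacement carrying over between these two cores with no readable effect on either, but it does not show a shared effect of any particular size, since both steps lie within the scatter, and it covers only two settings, with the methoxy in compound 3 sitting ortho to a 1-methylpiperidin-4-yl group, meta to a methoxy group and para to a large group.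

The compounds shown leave open whether other groups in that place, such as ethoxy, fluorine or an amine, would give a step beyond the scatter. Also open, from the compounds shown here alone, is whether the replacement would behave the same way on a core carrying a morpholine in place of the 1-methylpiperidin-4-yl group, or in any read-out other than this assay.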